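The source may hold more compounds than are shown below. What is called first, only, known or untested is meant among the compounds shown, and "the series" means these compounds.

The compounds share one core, seen in compound 1 `C[C@H](c1ccc(C(=O)NCCC(=O)O)cc1)N1C(=O)C(c2cccc(OC(F)(F)F)c2)=N[C@]12CC[C@@H](C(C)(C)C)CC2`, compound 2 `CCC[C@H](c1ccc(C(=O)NCc2nn[nH]n2)cc1)N1C(=O)C(c2cc(Cl)cc(Cl)c2)=N[C@]12CC[C@@H](C(C)(C)C)CC2` and compound 3 `CC(C)(C)CC[C@H](c1ccc(C(=O)NCc2nn[nH]n2)cc1)N1C(=O)C(c2cc(Cl)cc(Cl)c2)=NC12CCCCC2`. In an assay on CHO cells for displacement of a labelled ligand from Glucagon receptor (Homo sapiens), read by scintillation counting, with a stated time of 60 min (a higher number here means a weaker inhibitor, a lower number a stronger inhibitor), compound 1 gives 330 nM. In this assay compound 2 gives 55 nM. In this assay compound 3 gives 195 nM, the second highest of the three numbers; the number of compound 1 lies within the usual scatter of it, so no order can be read between those two, while the number of compound 2 is clearly lower than that of compound 3, beyond the scatter. Compound 2 and compound 3 differ in more than one place. Among the compounds with values here, no single step between them is available.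

Compound 4 `CC[C@H]1CC[C@]2(CC1)N=C(c1cc(Cl)cc(Cl)c1)C(=O)N2[C@H](CCC(C)(C)C)c1ccc(C(=O)NCc2nn[nH]n2)cc1` differs from compound 3 by ethyl in place of hydrogen on a saturated ring carbon. Within the data shown here, no measured pair in this set isolates that change. Compound 2, which carries a tert-butyl group on the same saturated ring and gives 55 nM, hints that a branch on that ring may go with a lower number, though its other differences cloud the reading. A moderate step down in this assay is expected, a 2.0-fold lower number from compound 3 to compound 4 (0.29 log units; within the scatter), but with wide uncertainty. Compound 4 is therefore estimated at 100 nM, within a range from 40 nM to 300 nM.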

Compound 4, half-maximal inhibitory concentration: 44 nM
Compound 4: the middle estimate sits 2.3-fold (0.36 log units) above what was measured, within the range that was stated.
By their numbers in this assay, from the lowest: compounds 4 and 2 (each within the scatter of the next); then compounds 3 and 1 (each within the scatter of the next).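

In this assay, within the data shown here, this pair gives the first reading of a single change at this position: ethyl in place of hydrogen on a saturated ring carbon, three ring bonds from the ring atom that bears two fused rings, gives a 4.4-fold lower number from compound 3 to compound 4 (0.65 log units; beyond the scatter). Compound 2 could only hint at a link between a branch on that ring and the number, as it differs from compound 3 in more than one place, whereas here the ethyl group is the only difference, and it enters with no ring, no hydrogen-bond donors or acceptors and no net charge. Nothing at hand explains why the number moves with this change.

From the compounds shown here alone, it remains open how a methyl, a propyl or a tert-butyl group would compare with ethyl on the same ring carbon as a single change, or whether a hydroxyl group or an amine there would move the number at all, since the tert-butyl group of compound 2 stands alongside other differences. Going by these compounds, the step also rests on one pair, so whether it holds with other groups elsewhere on the shared core, such as the propanoic acid side chain of compound 1, remains unknown.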